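The compounds below may be only part of what the source reports. "The series", "measured", "known", "first", "only" and "open" are said of these compounds alone.

- Compound 1 `C=C(CC)C(=O)c1ccc(OCC(=O)NCCCN2CCCC2=O)c(Cl)c1Cl`: 13800 nM
- Compound 2 `C=C(CC)C(=O)c1ccc(OCC(=O)Nc2ccc(O)c([N+](=O)[O-])c2)c(Cl)c1Cl`: 7400 nM
- Compound 3 `C=C(CC)C(=O)c1ccc(OCC(=O)Nc2ccc3c(c2)C(=O)NC3=O)c(Cl)c1Cl`: 2500 nM

These three compounds were tested in a functional assay on CLL cells (Homo sapiens) for cytotoxicity, read by MTT assay, with a stated time of 48 h; a higher number here means that more compound is needed for the effect, a lower number that less compound is needed. Compound 1, at 13800 nM, and compound 2, at 7400 nM, lie within the usual scatter of each other. Compound 3, at 2500 nM, has a number clearly lower than that of compound 1, and this gap lies beyond the scatter. Compound 1 therefore sits at the upper end of this small set, level with compound 2 within the scatter.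

The next compound to be tested is compound 4 `C=C(CC)C(=O)c1ccc(OCC(=O)NC(CS)C(=O)OCC)c(Cl)c1Cl`. It keeps the core of compound 1 but carries 1-(ethoxycarbonyl)-2-sulfanylethyl in place of 3-(2-oxopyrrolidin-1-yl)propyl on an amide-type nitrogen.

Among the compounds with values here, no two measured compounds differ in only one place, so no single change has been measured directly, and any forecast here is rough. Compound 3, at 2500 nM, shows that a different group on that nitrogen can go with a lower number than compound 1 has. A modest move towards a lower number is therefore expected in this assay, with a wide margin. The expected change is a 2.3-fold lower number from compound 1 to compound 4 (0.36 log units; beyond the scatter). Compound 4 is estimated at 6000 nM, with an expected range from 2000 nM to 16000 nM.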

Compound 4, half-maximal effective concentration: 4800 nM
Compound 4: middle estimate off by 1.3-fold (0.10 log units), on the high side; the measured number falls inside the stated range.
By their numbers in this assay, from the lowest: compounds 3, 4, 2 and 1 (each within the scatter of the next, the first and the last beyond it).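

Putting 1-(ethoxycarbonyl)-2-sulfanylethyl in place of 3-(2-oxopyrrolidin-1-yl)propyl on the amide-type nitrogen gives, in this assay, a 2.9-fold lower number from compound 1 to compound 4 (0.46 log units; beyond the scatter). Within the data shown here, this is the first comparison in the set in which only one place differs, so it shows that the group on this nitrogen can move the number by itself while the shared core stays the same. It also shows that the five-membered ring of the leaving group is not needed to reach this level of cytotoxicity, although no measured evidence here explains why the number falls.

The change removes a whole group and brings in a sulfanyl and an ethoxycarbonyl together, so the compounds shown leave open which part of the new group goes with the lower number. Compounds with a carboxylic acid in place of the ethoxycarbonyl, or with a plain alkyl chain that has no sulfanyl, would separate these two parts, and an amine on the chain would test a further kind of group at this nitrogen.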